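A few compounds are considered here, and "the series" means these few. Any claim that something is new, unique, unknown or untested is made for them only; others in the source may bear on it.

The measurements come from an ADME assay on L1210/0 cells (Mus musculus) for cytotoxicity, with a stated time of 48 h; a lower number here means a stronger inhibitor, a higher number a weaker inhibitor. For the measured compounds named here, compound 1, `C=Cc1cn([C@H]2C[C@H](O)[C@@H](CO)O2)c(=O)[nH]c1=O`, is the only compound with a plain number in this assay: compound 1 gives 14200 nM. Compound 2, `C[C@H](O)C1CC(CCn2cnc3c(N)ncnc32)C1(C)C`, is the other tested compound, and in this assay compound 2 gives > 200000 nM, which is a limit of the assay and not a number; it is the limit of > 200000 nM in this assay, at which 1 of the 2 values shown sits. Compound 3, `CS(=O)(=O)Cc1cn([C@H]2C[C@H](O)[C@@H](CO)O2)c(=O)[nH]c1=O`, has not yet been measured in this assay. Compound 3 differs from compound 1 in one place: (methylsulfonyl)methyl in place of vinyl on an aromatic carbon. Going by the values given here, no step between two measured compounds that differ in one place is available, so nothing measured shows how a change of this kind acts in this assay. The expectation is nonetheless that compound 3 will come out as a weaker inhibitor than compound 1, with the step of a 4.2-fold higher number from compound 1 to compound 3 (0.63 log units; beyond the scatter) expected to lie beyond the usual scatter. The estimated value for compound 3 in this assay is 60000 nM, with a range from 12000 nM to 200000 nM, and there is a fair chance that the assay reports only a limit for compound 3.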

Compound 3, half-maximal inhibitory concentration: > 200000 nM
Compound 3: no number, only a limit (the forecaster's own chance of this, stated with the estimate: 35%); middle value at least 3.3-fold (0.52 log units) from the limit.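

The aromatic carbon that carries vinyl now has its first measured change in this assay: (methylsulfonyl)methyl in place of vinyl gives an at least 14-fold higher number from compound 1 to compound 3 (1.14 log units; beyond the scatter). For the compounds shown here, this single change, with the rest of the molecule kept, is enough to turn a readable number into a limit, something the earlier compounds could not show, as they differ in more than one place. The value for compound 3 is a limit of the assay and not a number, so the size of the step is only a minimum, and compound 3 now stands with compound 2: the limit of > 200000 nM in this assay, at which 2 of the 3 values shown sit.

Only one replacement at this carbon is shown, so it stays open whether the rise belongs to the sulfonyl part of the new group or whether almost any group in place of vinyl would do the same. From the compounds shown here alone, an ethyl group or an aminomethyl group on the same carbon could help to separate these two readings, and how far beyond the limit compound 3 really lies also remains unknown.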